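Swapping a ring-bearing substituent for chloro on the core

The compounds below may be only part of what the source reports. "The series", "measured", "known", "first", "only" and "open" are said of these compounds alone.

The measured compounds and their numbers are:

compound 1, `CC(C(=O)NCc1ccc(C(F)(F)F)cc1N1CCC(C(F)(F)F)CC1)c1ccc(NS(C)(=O)=O)c(F)c1`, 0.4 nM
compound 2, `CC(C(=O)NCc1ccc(C(F)(F)F)cc1OC1CCCC1)c1ccc(NS(C)(=O)=O)c(F)c1`, 0.6 nM
compound 3, `CC(C(=O)NCc1ccc(C(F)(F)F)cc1SC1CCCCC1)c1ccc(NS(C)(=O)=O)c(F)c1`, 0.5 nM

All three were read in an assay on CHO cells for antagonist activity at transient receptor potential cation channel subfamily V member 1 (Homo sapiens), read by FLIPR; on this read-out lower numbers stand for stronger inhibition and higher numbers for weaker inhibition. Compound 3 lies with the other two in one narrow band: the step of a 1.3-fold higher number from compound 1 to compound 3 (0.10 log units; within the scatter) and the step of a 1.2-fold lower number from compound 2 to compound 3 (0.08 log units; within the scatter) both fall within the scatter, as does the step of a 1.5-fold higher number from compound 1 to compound 2 (0.18 log units; within the scatter). Across these three, exchanging one ring-bearing group on that aromatic carbon for another leaves the number essentially unchanged.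

Compound 4, `CC(C(=O)NCc1ccc(C(F)(F)F)cc1Cl)c1ccc(NS(C)(=O)=O)c(F)c1`, has not yet been measured in this assay. It differs from compound 3 in one place: chloro in place of cyclohexylsulfanyl on an aromatic carbon. For the measured compounds named here, none of the measured steps covers this kind of change; each of them replaced one group carrying a non-aromatic ring with another such group, whereas here the ring is removed altogether and only a single chlorine remains. The measured steps therefore show that the three ring-bearing groups are interchangeable, but say nothing direct about a group this small. Some loss of inhibition beyond the scatter is the more likely outcome, although its size is uncertain. For compound 4 the expected value in this assay is 3 nM, with a range from 0.5 nM to 20 nM. This expectation corresponds to the step of a 6.0-fold higher number from compound 3 to compound 4 (0.78 log units; beyond the scatter).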

Compound 4, inhibition constant: 4 nM
Compound 4: middle estimate off by 1.3-fold (0.12 log units), on the low side; low and high end bracket the measured number.
By their numbers in this assay, from the lowest: compounds 1, 3 and 2 (each within the scatter of the next); then compound 4.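

The change to chloro on this aromatic carbon, ortho to a large group and meta to a trifluoromethyl group, is the only change shown that moves the number in this assay beyond the scatter: the step is an 8.0-fold higher number from compound 3 to compound 4 (0.90 log units; beyond the scatter) and, with the other two ring-bearing groups as the starting point, a 6.7-fold higher number from compound 2 to compound 4 (0.82 log units; beyond the scatter) and a 10-fold higher number from compound 1 to compound 4 (1.00 log units; beyond the scatter) in turn. The interchangeability of cyclohexylsulfanyl, cyclopentyloxy and 4-(trifluoromethyl)piperidin-1-yl therefore does not extend to a single chlorine, and inhibition is weaker with chloro than with any of the three, though all three steps are of modest size. No measurement shown accounts for this loss.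

For the compounds shown here, with chloro as the only small group, the compounds leave open how much of a ring-bearing group this position needs: a plain hydrogen, a methoxy group or an open butyloxy chain could show whether the number falls gradually or only once a ring is present. They also leave open whether a group carrying an amine or a carboxylic acid here would stay in the narrow band of compound 1, compound 2 and compound 3.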